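A Phenyl Ring Replaces the Pyrazole at the Aniline Nitrogen

The compounds below may be only part of what the source reports. "The series", "measured", "known", "first", "only" and "open" are said of these compounds alone.

In a functional assay on MCF7 cells (Homo sapiens) for antiproliferative activity, read by sulforhodamine B assay, with a stated time of 72 h (a higher number here means a weaker inhibitor, a lower number a stronger inhibitor), compound 2 `COc1ncc(-c2ccc3ncnc(Nc4cnn(CCCO)c4)c3c2)cc1NS(=O)(=O)c1ccc(F)cc1F` gives 1310 nM. Within the data shown here, compound 2 holds the highest of the two numbers measured so far, and its nearest neighbour is compound 1 `COC(=O)Cn1cc(Nc2ncnc3ccc(-c4cnc(OC)c(NS(=O)(=O)c5ccc(F)cc5F)c4)cc23)cn1`, which gives 670 nM; the change is a 2.0-fold higher number from compound 1 to compound 2 (0.29 log units; within the scatter), so the two stand within the scatter of each other. Compound 3 `COc1cc(Nc2ncnc3ccc(-c4cnc(OC)c(NS(=O)(=O)c5ccc(F)cc5F)c4)cc23)ccc1OCCO` differs from compound 2 by 4-(2-hydroxyethoxy)-3-methoxyphenyl in place of 1-(3-hydroxypropyl)-1H-pyrazol-4-yl on a nitrogen on an aromatic ring. Among the measured compounds shown here, the single measured step altered a chain on that same five-membered ring and stayed within the scatter; no measured step exchanges the ring itself, so the record gives little guidance. The analyst therefore expects for compound 3 a step of a 1.3-fold lower number from compound 2 to compound 3 (0.12 log units; within the scatter) in this assay, nothing beyond the scatter in either direction, with a wide range. The estimate for compound 3 is 1000 nM, between 250 nM and 4000 nM.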

Compound 3, half-maximal inhibitory concentration: 2260 nM
The estimate for compound 3 lay 2.3-fold (0.35 log units) below the measured number; low and high end bracket the measured number.
By their numbers in this assay, from the lowest: compounds 1, 2 and 3 (each within the scatter of the next, the first and the last beyond it).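

In this assay, among these compounds, the first exchange of the whole ring on this aromatic nitrogen, 4-(2-hydroxyethoxy)-3-methoxyphenyl for 1-(3-hydroxypropyl)-1H-pyrazol-4-yl, stays within the scatter (a 1.7-fold higher number from compound 2 to compound 3 (0.24 log units; within the scatter)), so a six-membered aromatic ring of carbon only is tolerated here in place of the five-membered one. Set against 1-((methoxycarbonyl)methyl)-1H-pyrazol-4-yl, the same phenyl group gives the first step in this series to pass beyond the scatter (a 3.4-fold higher number from compound 1 to compound 3 (0.53 log units; beyond the scatter)), though it is modest and rests on a single pair. Nothing at hand bears on the cause of either step.

From the compounds shown here alone, it remains open whether the 2-hydroxyethoxy group or the methoxy group matters to the reading, since both enter together. Also open, going by these compounds, is how a phenyl ring bearing an amine or a carboxylic acid on a longer chain would read.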